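Phenoxy for butoxy on the aryl of the tetralin amine series

The source may hold more compounds than are shown below. What is called first, only, known or untested is meant among the compounds shown, and "the series" means these compounds.

Compound 3 `CCCCOc1ccc([C@@H]2CC[C@@H](NC)c3ccccc32)cc1` gives 1150 nM in a functional assay on Hypothalamus for inhibition of Norepinephrine transporter (Rattus norvegicus); a lower number here means a stronger inhibitor, a higher number a weaker inhibitor. It sits at the high end of the three numbers: compound 2 `CN[C@@H]1CC[C@@H](c2ccc(Cl)cc2Cl)c2ccccc21` at 970 nM lies within the scatter of it, while compound 1 `CN[C@@H]1CC[C@@H](c2ccc(F)cc2)c2ccccc21` at 30 nM lies far below, the step of a 38-fold higher number from compound 1 to compound 3 (1.58 log units; beyond the scatter) being large. Compound 4 `CN[C@@H]1CC[C@@H](c2ccc(Oc3ccccc3)cc2)c2ccccc21` carries the change (phenyl in place of butyl on an oxygen on an aromatic ring). Among the measured compounds shown here, no measured pair covers phenyl against butyl on that oxygen; the only step that bears on it, from compound 1 to compound 3, shows that enlarging this substituent raised the number strongly, and compound 2 adds nothing on the oxygen position. The step of a 1.3-fold higher number from compound 3 to compound 4 (0.12 log units; within the scatter) is therefore expected to be small, likely within the scatter. For compound 4 the expected value is 1500 nM, with a range of 500 nM to 5000 nM.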

Compound 4, half-maximal inhibitory concentration: 2300 nM
Compound 4: middle estimate off by 1.5-fold (0.19 log units), on the low side; the measured number falls inside the stated range.
By their numbers in this assay, from the lowest: compound 1; then compounds 2, 3 and 4 (each within the scatter of the next, the first and the last beyond it).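

In this assay phenyl in place of butyl on the oxygen gives a 2.0-fold higher number from compound 3 to compound 4 (0.30 log units; within the scatter), so an aromatic ring and an open chain at this place cannot be told apart. The step of a 77-fold higher number from compound 1 to compound 4 (1.88 log units; beyond the scatter) is large and shows that the loss seen with butoxy against fluoro is not peculiar to the butyl chain. No measurement here accounts for this loss.

Open, from the compounds shown here alone, is whether methoxy, the smallest ether on this carbon, stays close to compound 1 or falls with compound 3 and compound 4 . Also open, going by these compounds, is how a hydroxyl or a benzyloxy group would read at the same place.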